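A few compounds are considered here, and "the series" means these few. Any claim that something is new, unique, unknown or untested is made for them only; others in the source may bear on it.

Compound 1 (`Cc1cc(OCc2ccc(F)cc2F)c(Br)c(=O)n1Cc1cccc(CN(C)C)c1`) and compound 2 (`Cc1cc(OCc2ccc(F)cc2F)c(Br)c(=O)n1Cc1ccc(C(=O)N(C)C)cc1`) share a core but differ in more than one place. In an ADME assay on microsomes from liver (Homo sapiens) for metabolic stability, read by LC-MS, with a stated time of 45 min, tested at 2 uM (a higher number here means that more of the compound is left, a lower number that less of the compound is left), compound 1 gives 50% and compound 2 gives 59% as its reading. That gap lies within the usual scatter, so compound 2 stands level with compound 1 and neither can be ranked above the other. Compound 3 (`Cc1cc(OCc2ccc(F)cc2F)c(Br)c(=O)n1Cc1ccc(C(N)=O)cc1`) has not yet been measured. Compared with compound 2, it carries amino in place of dimethylamino on a carbonyl carbon and is otherwise unchanged. For the measured compounds named here, no measured pair differing in a single place is available as a guide, so the expectation rests on this change alone. A modest rise is expected, with the estimated move a number 7 percentage points higher from compound 2 to compound 3 (within the scatter) lying close to the edge of the scatter. For compound 3 the expected value is 66% with an estimated range from 48% to 84% in this assay.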

Compound 3, percent of the compound remaining: 89%
For compound 3 the middle estimate is 23 percentage points below the measured one, outside the stated range (above it).
By their numbers in this assay, from the lowest: compounds 1 and 2 (each within the scatter of the next); then compound 3.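

In this assay, amino in place of dimethylamino on a carbonyl carbon, whose other neighbour is an aromatic carbon, gives a number 30 percentage points higher from compound 2 to compound 3 (beyond the scatter), which shows that this one change at the end of the amide is enough to move the reading beyond the scatter. The carbamoyl compound also stands clear of the amine-bearing one: 4-carbamoylphenyl in place of 3-((dimethylamino)methyl)phenyl, on a saturated chain carbon bound to an aromatic nitrogen, gives a number 39 percentage points higher from compound 1 to compound 3 (beyond the scatter). Nothing available explains why the reading rises with either change.

On these data alone, whether methylamino on the same carbonyl carbon would read nearer compound 2 or compound 3 remains open, as does the outcome with a carboxylic acid or a nitrile in place of the carbamoyl group. The compounds shown also leave open whether the step from dimethylamino to amino would recur on another core.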